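Swapping the Aryl Group on the Amide-Type Nitrogen

A few compounds are considered here, and "the series" means these few. Any claim that something is new, unique, unknown or untested is made for them only; others in the source may bear on it.

Compound 1, `O=C(Nc1cccc(-n2cc(-c3ccncc3)c(-c3ccc(Cl)c(O)c3)n2)c1)Nc1ccc(Cl)c(Cl)c1`, gives 24200 nM in a functional assay on NCI-H460 cells (Homo sapiens) for inhibition, read by sulforhodamine B assay, with a stated time of 48 h; on this read-out lower numbers stand for higher toxicity in this test and higher numbers for lower toxicity in this test.
Compound 2, `COc1cc(-c2nn(-c3cccc(NC(=O)c4ccc(Cl)c(C(F)(F)F)c4)c3)cc2-c2ccncc2)ccc1Cl`, gives > 32500 nM, a limit of the assay rather than a number.
Compound 3, `COc1cc(-c2nn(-c3cccc(NC(=O)Nc4ccc(Cl)c(C(F)(F)F)c4)c3)cc2-c2ccncc2)ccc1Cl`, gives > 32500 nM, likewise a limit.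

Compound 1 is the only one of the three with a measured number; the other two sit at the limit of > 32500 nM in this assay, at which 2 of the 3 values shown sit. Going by the values given here, the single step between measured compounds, a step that the two limits leave unreadable from compound 2 to compound 3, changes the carbonyl side of the molecule and its size cannot be read, since both ends are limits. It therefore says nothing about the change now in question.

Compound 4, `O=C(Nc1cccc(-n2cc(-c3ccncc3)c(-c3ccc(Cl)c(O)c3)n2)c1)Nc1cccc(C(F)(F)F)c1`, differs from compound 1 by 3-(trifluoromethyl)phenyl in place of 3,4-dichlorophenyl on an amide-type nitrogen. Among the compounds with values here, no measured step touches this position, so the expectation rests on compound 1 alone. The step from compound 1 to compound 4 is expected to be a 1.1-fold higher number from compound 1 to compound 4 (0.03 log units; within the scatter), that is, nothing beyond the usual scatter. Compound 4 is accordingly estimated at 26000 nM, with a range from 11000 nM to 60000 nM, and because two of three values sit at the limit of > 32500 nM in this assay, at which 2 of the 3 values shown sit, a limit instead of a number remains a real possibility.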

Compound 4, concentration lethal to 50% of the cells: > 32500 nM
Compound 4: no number, only a limit (the forecaster's own chance of this, stated with the estimate: 40%); middle value at least 1.2-fold (0.09 log units) from the limit.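

On an amide-type nitrogen, 3-(trifluoromethyl)phenyl in place of 3,4-dichlorophenyl gives in this assay an at least 1.3-fold higher number from compound 1 to compound 4 (0.12 log units; that floor lies within the scatter). Going by these compounds alone, this is the first reading at this position, but it is only a floor, so the true size of the step could be small or much larger. Compound 1 remains the only compound with a measured number, and compound 4 joins the others at the same limit: the limit of > 32500 nM in this assay, at which 3 of the 4 values shown sit.

As far as these compounds go, what stays open is whether any other group on this nitrogen would give a number clearly lower than that of compound 1, or a measurable number at all. A phenyl ring carrying an amine or a carboxylic acid, or a plain phenyl ring with a single chlorine, would test how far the result depends on the aryl group found here.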